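Swapping methoxy for methyl on compound 1

The source may report more compounds than this note shows. Statements on the series, on what has been measured and on what is new or still open speak of the compounds shown alone.

For the measured compounds named here, in a functional assay on FM3A cells (Mus musculus) for antiproliferative activity, read by cell counting, with a stated time of 2 days (a lower number here means a stronger inhibitor, a higher number a weaker inhibitor), compound 1 `COc1ccc(Nc2nc(N)c(C(=O)c3ccccc3)s2)cc1` gives 730 nM as the higher of the two numbers so far, and compound 2 `COc1ccc(Nc2nc(N)c(C(=O)c3cccc(OC)c3)s2)cc1` gives 50 nM as the lower. Compound 3 `Cc1ccc(Nc2nc(N)c(C(=O)c3ccccc3)s2)cc1` keeps the core of compound 1. The change methyl in place of methoxy on an aromatic carbon puts methyl in place of methoxy on an aromatic carbon, para to a large group. Going by the values given here, the only measured step of a 15-fold lower number from compound 1 to compound 2 (1.16 log units; beyond the scatter) is large, but it comes from methoxy in place of hydrogen elsewhere in the molecule, so it gives no direct guide here. The expected step of a 1.2-fold higher number from compound 1 to compound 3 (0.09 log units; within the scatter) therefore stays within the scatter. Compound 3 is estimated at 900 nM with 250 nM to 3000 nM as the expected range.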

Compound 3, half-maximal inhibitory concentration: 1500 nM
The estimate for compound 3 lay 1.7-fold (0.22 log units) below the measured number; low and high end bracket the measured number.
By their numbers in this assay, from the lowest: compound 2; then compound 1; then compound 3.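

In this assay, for the compounds shown here, the step of a 2.1-fold higher number from compound 1 to compound 3 (0.31 log units; beyond the scatter) gives the first reading at this position, on the aromatic carbon para to a large group. It is modest but beyond the scatter, so methoxy and methyl are not interchangeable here, and compound 1 with methoxy has the lower number. Nothing measured here gives a reason for this difference. The compounds shown leave open how an amine or a chlorine at this place would read, and whether the same swap on compound 2 would give a similar step.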